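The source may hold more compounds than are shown below. What is called first, only, known or untested is meant among the compounds shown, and "the series" means these compounds.

Measured compounds in a functional assay on MCF7 cells (Homo sapiens) for antiproliferative activity, read by sulforhodamine B assay, with a stated time of 48 h; on this read-out higher numbers stand for weaker inhibition of growth and lower numbers for stronger inhibition of growth:
compound 1 `O=C(NCc1cn(Cc2ccc(Cl)cc2)nn1)c1cn(-c2ccccc2)nc1-c1ccc(F)cc1` — 130 nM
compound 2 `O=C(NCc1cn(Cc2ccc(C(F)(F)F)cc2)nn1)c1cn(-c2ccccc2)nc1-c1ccc(F)cc1` — 810 nM
compound 3 `O=C(NCc1cn(Cc2ccc(Cl)cc2)nn1)c1cn(-c2ccccc2)nc1-c1ccc(Cl)cc1` — 28800 nM

Compound 3 stands at the highest number of the three; its nearest neighbour is compound 2 and the furthest is compound 1. From compound 1 to compound 2 the change is trifluoromethyl in place of chloro on an aromatic carbon, and it gave a 6.2-fold higher number from compound 1 to compound 2 (0.79 log units; beyond the scatter). The core of compound 3 differs from the core of compound 1 by chloro in place of fluoro on an aromatic carbon, a change that gave a 220-fold higher number from compound 1 to compound 3 (2.35 log units; beyond the scatter).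

Compound 4 `O=C(NCc1cn(Cc2ccc(C(F)(F)F)cc2)nn1)c1cn(-c2ccccc2)nc1-c1ccc(Cl)cc1` is not yet measured in this assay. It differs from compound 3 by trifluoromethyl in place of chloro on an aromatic carbon, the same change as that from compound 1 to compound 2, made here on the core that carries chloro rather than fluoro. Beside the earlier step, the step from compound 3 to compound 4 is expected to be a 4.2-fold higher number from compound 3 to compound 4 (0.62 log units; beyond the scatter); this rests on compound 1 and compound 2 alone, where the change gave a 6.2-fold higher number from compound 1 to compound 2 (0.79 log units; beyond the scatter), with no second instance to show whether the size carries over onto the chloro core. The number for compound 4 is estimated at 120000 nM, between 30000 nM and 400000 nM, and at this height the assay may report only a limit.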

Compound 4, concentration for 50% growth inhibition: 4900 nM
The estimate for compound 4 lay 24-fold (1.39 log units) above the measured number; the measured number lies below the stated range.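

In this assay, trifluoromethyl in place of chloro gave a 5.9-fold lower number from compound 3 to compound 4 (0.77 log units; beyond the scatter), the opposite direction to the step on the core carrying fluoro, so neither the size nor the direction of this change carries over from one core to the other: the same change on two cores in this assay, a 6.2-fold higher number (0.79 log units; beyond the scatter) from compound 1 to compound 2 and a 5.9-fold lower number (0.77 log units; beyond the scatter) from compound 3 to compound 4, 37-fold (1.56 log units) apart, beyond the scatter of two such steps

Chloro in place of fluoro gave a 6.0-fold higher number from compound 2 to compound 4 (0.78 log units; beyond the scatter), the same direction as on the core with the 4-chlorobenzyl group but a much smaller step: the same change on two cores in this assay, a 220-fold higher number (2.35 log units; beyond the scatter) from compound 1 to compound 3 and a 6.0-fold higher number (0.78 log units; beyond the scatter) from compound 2 to compound 4, 37-fold (1.56 log units) apart, beyond the scatter of two such steps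

The two changes therefore do not act independently across compounds 1 to 4, but this single closed set of four does not show why, nor whether any other pair of groups would behave in the same way.

Still open, going by these compounds, is whether bromo or methoxy in place of the chloro of the 4-chlorophenyl group would follow the fluoro or the chloro pattern. Also open, on these data alone, is how a nitrile or an amine in place of the trifluoromethyl of the 4-(trifluoromethyl)benzyl group would behave on each core.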